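Removing the Para-Ring Substituent on a Bifuran Amidine

A few compounds are considered here, and "the series" means these few. Any claim that something is new, unique, unknown or untested is made for them only; others in the source may bear on it.

Measured compounds:
compound 1, `N=C(N)c1ccc(-c2ccc(-c3ccc(F)cc3)o2)o1`: 1220 nM
compound 2, `COc1ccc(-c2ccc(-c3ccc(C(=N)N)o3)o2)cc1`: 1880 nM

Two analogues with the same shared core have been measured in a functional assay on PC-3 cells (Homo sapiens) for inhibition, read by sulforhodamine B assay, with a stated time of 48 h; a lower number here means a stronger inhibitor of growth, a higher number a weaker inhibitor of growth. Compound 1 gives 1220 nM, and compound 2 gives 1880 nM. Within the data shown here, the single step between them, a 1.5-fold higher number from compound 1 to compound 2 (0.19 log units; within the scatter), is the only one available; it has methoxy in place of fluoro on an aromatic carbon. Compound 2 thus carries the highest of the two numbers, but its step to compound 1 lies within the scatter, so no order between the two can be claimed.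

Compound 3, `N=C(N)c1ccc(-c2ccc(-c3ccccc3)o2)o1`, has not been measured in this assay . It differs from compound 2 in one place: hydrogen in place of methoxy on an aromatic carbon, on an aromatic carbon of a six-membered aromatic ring of carbon only. The one measured step bears on it only loosely: changing fluoro to methoxy at that carbon produced a step within the scatter, so the substituent at that carbon appears to matter little among these compounds. Compound 3 is therefore expected to stay near the two measured values, with a step of a 1.3-fold lower number from compound 2 to compound 3 (0.10 log units; within the scatter) that does not exceed the scatter. The estimate for compound 3 in this assay is 1500 nM, with a range from 600 nM to 4000 nM.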

Compound 3, concentration for 50% growth inhibition: 2640 nM
The estimate for compound 3 lay 1.8-fold (0.25 log units) below the measured number; the measured number falls inside the stated range.
By their numbers in this assay, from the lowest: compounds 1, 2 and 3 (each within the scatter of the next, the first and the last beyond it).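

In this assay, hydrogen in place of methoxy on this aromatic carbon, para to a large group, gives a 1.4-fold higher number from compound 2 to compound 3 (0.15 log units; within the scatter) and so does not separate the two compounds, which shows that a ring without any substituent at this carbon can stay within the scatter of the methoxy compound. Hydrogen in place of fluoro gives the first step at this carbon that lies beyond the scatter, a 2.2-fold higher number from compound 1 to compound 3 (0.34 log units; beyond the scatter), although it is modest, so the substituent here is not wholly without consequence, yet compound 2 cannot be ordered against either neighbour and therefore goes against any simple rule that a substituent at this carbon lowers the number. No measurement is at hand that would account for this step.

With only fluoro, methoxy and hydrogen shown at this carbon, it remains open whether chloro, trifluoromethyl, hydroxy or an amine there would extend the gap between compound 1 and compound 3 or stay within the same narrow band. Going by these compounds, it also remains open whether a carboxylic acid or a longer chain such as butoxy at this carbon would give a step clearly beyond the scatter.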